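The source may hold more compounds than are shown below. What is called first, only, known or untested is meant among the compounds shown, and "the series" means these compounds.

Among the measured compounds shown here, in an ADME assay on microsomes from liver (Mus musculus) for metabolic stability, read by LC-MS, with a stated time of 30 min, tested at 1 uM (on this read-out higher numbers stand for a more stable compound and lower numbers for a less stable compound), compound 1 (`CC(C)C1=C(C(=O)N2[C@H](C)CC[C@H]2C(=O)N2CCN(C)CC2)SC2=N[C@@](C)(c3ccc(Cl)cc3)[C@@H](c3ccc(Cl)cc3)N21`) gives 25%, the middle of the three numbers measured so far. Compound 2 (`CC[C@@H]1CC[C@@H](C(=O)N2CCN(C)CC2)N1C(=O)C1=C(C(C)C)N2C(=N[C@@](C)(c3ccc(Cl)cc3)[C@H]2c2ccc(Cl)cc2)S1`) stands at 50%, and compound 3 (`CC[C@@H]1CC[C@@H](C(=O)N2CCOCC2)N1C(=O)C1=C(C(C)C)N2C(=N[C@@](C)(c3ccc(Cl)cc3)[C@H]2c2ccc(Cl)cc2)S1`) stands at 6%.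

Compound 4 (`CC(=O)N1CCN(C(=O)[C@@H]2CC[C@@H](C)N2C(=O)C2=C(C(C)C)N3C(=N[C@@](C)(c4ccc(Cl)cc4)[C@H]3c3ccc(Cl)cc3)S2)C[C@H]1C`) keeps the core of compound 1 and differs in one place, on a carbonyl carbon whose other neighbour is a saturated ring carbon: a group of 10 heavy atoms (7 carbon, 2 nitrogen, 1 oxygen; one six-membered non-aromatic ring with 2 hetero atoms) in place of a group of 7 heavy atoms (5 carbon, 2 nitrogen; one six-membered non-aromatic ring with 2 hetero atoms), on a carbonyl carbon. The group that leaves is 4-methylpiperazin-1-yl.

Two measured steps can be weighed here. The more relevant one happens at the same kind of place: morpholin-4-yl in place of 4-methylpiperazin-1-yl on a carbonyl carbon gave a number 44 percentage points lower from compound 2 to compound 3 (beyond the scatter). The other, a number 25 percentage points higher from compound 1 to compound 2 (beyond the scatter), comes from methyl in place of hydrogen on a saturated chain carbon bound to a saturated ring carbon, a different place, so it offers little guidance. For the measured compounds named here, no measured compound carries the group that enters in compound 4, which makes any forecast uncertain. The single measured replacement of 4-methylpiperazin-1-yl went downward, so a modest fall is expected, smaller than that precedent, and a rise cannot be excluded. The expected change is a number 11 percentage points lower from compound 1 to compound 4 (beyond the scatter). For compound 4 the estimated value is 14%, with an expected range from 3% to 40%.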

Compound 4, percent of the compound remaining: 55%
Beside the measured number, compound 4's estimate is 41 percentage points below it, and the stated range ends below it.
By their numbers in this assay, from the lowest: compound 3; then compound 1; then compounds 2 and 4 (each within the scatter of the next).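

The carbonyl carbon whose other neighbour is a saturated ring carbon turns out to allow movement in both directions in this assay: the group of 10 heavy atoms in place of 4-methylpiperazin-1-yl gave a number 30 percentage points higher from compound 1 to compound 4 (beyond the scatter) and stands against morpholin-4-yl in place of the same group, which gave a number 44 percentage points lower from compound 2 to compound 3 (beyond the scatter) on a different starting compound. Losing 4-methylpiperazin-1-yl is therefore not enough on its own to lower the number, and for these two replacements the direction follows the group that enters. No measurement available here accounts for the rise.

The entering group differs from 4-methylpiperazin-1-yl in more than one feature, including its size, its double bond outside aromatic rings and its defined stereocentre, so the compounds shown do not tell which of these features goes with the higher number. From the compounds shown here alone, it also remains open how a simpler group on the same carbonyl carbon, such as piperidin-1-yl or dimethylamino, would move the number, and whether the entering group would give a similar step when placed on compound 2.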